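Working notes on tolerated concentration across four compounds

A few compounds are considered here, and "the series" means these few. Any claim that something is new, unique, unknown or untested is made for them only; others in the source may bear on it.

Measured so far:
compound 1 `O=C(Nc1ncc(Cc2ccc(Cl)cc2)s1)c1cccs1`: > 50000 nM
compound 2 `CC(C)(C)OC(=O)Nc1ncc(C(Oc2ccc(Br)cc2)c2ccc(Cl)cc2)s1`: > 50000 nM
compound 3 `CCOC(=O)CCCNc1ncc(C(Oc2ccc3cc(Br)ccc3c2)c2ccc(Cl)cc2)s1`: "not toxic" (no number reported)

All three were tested in an ADME assay on HepG2 2.2.15 cells (Homo sapiens) for cytotoxicity; a higher number here means that more compound is tolerated, a lower number that less compound is tolerated. For compound 1 the reading > 50000 nM is a limit of the assay and not a number. For compound 2 the reading > 50000 nM is likewise a limit. Compound 3 gives only the description "not toxic" (no number reported), with no number attached. Compound 3 therefore stands where nothing separates it from the others: no value in the set is a true number, and two of the three readings sit at the limit of > 50000 nM in this assay, at which 2 of the 3 values shown sit.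

Compound 4 `O=C(Nc1ncc(C(Oc2ccc3cc(Br)ccc3c2)c2ccc(Cl)cc2)s1)c1ccc(Br)cc1` is the next to be measured. It differs from compound 3 in one place: (4-bromophenyl)carbonyl in place of 3-(ethoxycarbonyl)propyl on a nitrogen on an aromatic ring. Among the compounds with values here, no pair of measured compounds differing in one place exists to set a size for such a change in this assay, and none of the measured values gives a direction. The expectation is a step of no size beyond the scatter, with the reading most probably again a limit rather than a number.

For compound 4 the estimate in this assay is 50000 nM, expected to fall between 20000 nM and 100000 nM.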

Compound 4, half-maximal cytotoxic concentration: > 50000 nM
Compound 4 gave a limit, no number; the forecaster's own chance of this, stated with the estimate: 70%; the middle value sits exactly at the limit.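

In this assay compound 4 gives > 50000 nM, which is a limit and not a number. Within the data shown here, compound 3 carries only the description "not toxic", so no step between compound 3 and compound 4 can be read. The compounds shown leave open whether (4-bromophenyl)carbonyl in place of 3-(ethoxycarbonyl)propyl changes the tolerated concentration at all.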